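One Hydroxy Group Fewer on Compound 1

The compounds below may be only part of what the source reports. "The series", "measured", "known", "first", "only" and "open" are said of these compounds alone.

In a functional assay on DU-145 cells (Homo sapiens) for inhibition, read by trypan blue exclusion, with a stated time of 96 h (on this read-out lower numbers stand for stronger inhibition of growth and higher numbers for weaker inhibition of growth), compound 1 `O=C(/C(=C\c1c(O)cc(O)cc1O)S(=O)(=O)c1ccccc1Br)c1ccc(Br)cc1` gives 50000 nM. Compound 3 `COc1ccc(/C=C(/Sc2ccc(Br)cc2)C(=O)c2ccc(Br)cc2)cc1` gives 25000 nM, which lies within the usual scatter of compound 1, so these two cannot be told apart. Compound 2 `O=C(/C(=C\c1ccc([N+](=O)[O-])c(O)c1)SCc1ccc(Br)cc1)c1ccc([N+](=O)[O-])cc1` gives 1000 nM, a number clearly lower than that of compound 1 and beyond the scatter. Compound 1 therefore sits, alongside compound 3, at the weak end of this small set, and compound 2 shows stronger inhibition of growth.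

Compound 4 `O=C(/C(=C\c1ccc(O)cc1O)S(=O)(=O)c1ccccc1Br)c1ccc(Br)cc1` has not yet been measured. It differs from compound 1 in a single place, where 2,4,6-trihydroxyphenyl becomes 2,4-dihydroxyphenyl: hydrogen in place of hydroxy on an aromatic carbon. For the measured compounds named here, no measured pair isolates this change, since compound 2 and compound 3 each differ from compound 1 in several places at once. With so little to go on, a small step with no clear direction is expected, leaving compound 4 close to compound 1, which gives 50000 nM. The estimated step is a 1.7-fold lower number from compound 1 to compound 4 (0.22 log units; within the scatter), which would stay within the scatter. For compound 4 the estimated value is 30000 nM, with an expected range from 8000 nM to 80000 nM.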

Compound 4, concentration for 50% growth inhibition: > 100000 nM
Compound 4 gave a limit, no number (the forecaster's own chance of this, stated with the estimate: 10%); at least 3.3-fold (0.52 log units) between middle value and limit.
By their numbers in this assay, from the lowest: compound 2; then compounds 3 and 1 (each within the scatter of the next). At a limit, above all of these: compound 4.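

In this assay compound 4 gives > 100000 nM, which is a limit of the assay and not a number. For the compounds shown here, the change from 2,4,6-trihydroxyphenyl to 2,4-dihydroxyphenyl comes with an at least 2.0-fold higher number from compound 1 to compound 4 (0.30 log units; that floor lies within the scatter), so this pair gives a direct reading of the hydroxy group on this aromatic carbon, which the earlier compounds, differing in several places at once, could not give. Hydrogen in place of this hydroxy group brought no stronger inhibition of growth, but how far the change goes in the other direction cannot be read, and the floor alone does not show a real loss; the reading for this pair stops at: the limit of > 100000 nM in this assay, at which 1 of the 4 values shown sits.

As far as these compounds go, what an amine or a carboxylic acid on this same aromatic carbon would do remains open, as does the effect of a small group such as fluorine there. Also open, from the compounds shown here alone, is whether removing this hydroxy group would read the same way on a compound whose value stays clear of the limit at both ends of the change, where the full size of the step could be seen.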